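From Compound 1 to Compound 4: One Side Chain Swapped

The source may report more compounds than this note shows. Statements on the series, on what has been measured and on what is new or still open speak of the compounds shown alone.

In a physicochemical assay for solubility, read by HPLC, using the shake flask method, measured as kinetic solubility, with a stated time of 20 h, at pH 6.5, tested at 200 uM (a lower number here means a less soluble compound, a higher number a more soluble compound), compound 1 (`O=S(=O)(NCC1COC1)c1cccc(-c2ccc3nccc(-c4ccncc4)c3n2)c1`) gives 20000 nM. This is the lower of the two exact numbers, since compound 2 (`O=S(=O)(NCCN1CCCC1)c1cccc(-c2ccc3nccc(-c4ccnc(C(F)(F)F)c4)c3n2)c1`) gives 145000 nM, a gap beyond the scatter. Compound 3 (`NS(=O)(=O)c1cccc(-c2ccc3nccc(-c4cccnc4)c3n2)c1`) gives only a limit, < 5000 nM.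

Compound 4 (`CS(=O)(=O)Nc1cccc(-c2ccc3nccc(-c4ccncc4)c3n2)c1`) carries methanesulfonamido in place of ((oxetan-3-yl)methyl)sulfamoyl on an aromatic carbon. Among the measured compounds shown here, no measured pair shows this swap alone, so the expectation starts from compound 1 at 20000 nM. A modest fall in this assay, close to the edge of the scatter, is expected: the estimated step of a 1.7-fold lower number from compound 1 to compound 4 (0.22 log units; within the scatter). Compound 4 is estimated at 12000 nM, with an expected range from 5000 nM to 35000 nM.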

Compound 4, solubility: 20000 nM
Compound 4: middle estimate off by 1.7-fold (0.22 log units), on the low side; the measured number falls inside the stated range.
By their numbers in this assay, from the lowest: compounds 1 and 4 (each within the scatter of the next); then compound 2. At a limit, below all of these: compound 3.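

With the rest of compound 1 unchanged, methanesulfonamido takes the place of ((oxetan-3-yl)methyl)sulfamoyl on this aromatic carbon, and this assay shows no change at the digits printed from compound 1 to compound 4 (within the scatter). Among the compounds shown here, this is the first comparison here that isolates one place, and at this position the four-membered ring can go, along with the larger side chain, without the number moving. Only compound 3 gives a limit rather than a number, so this step rests on two exact readings: the limit of < 5000 nM in this assay, at which 1 of the 4 values shown sits.

On these data alone, whether a carboxylic acid or a nitrile on the same carbon would also leave the number in place stays open. So does whether this swap would give the same result with a different group elsewhere on the molecule.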